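Chloro for trifluoromethoxy on the phenoxy arm of compound 1

The compounds below may be only part of what the source reports. "The series", "measured", "known", "first", "only" and "open" are said of these compounds alone.

Compound 1 `CCC1(O)CCN(c2nc(C)c3cc(NC(=O)COc4ccc(OC(F)(F)F)cc4)ccc3n2)CC1` gives 116 nM in an assay on CHO-K1 cells for displacement of a labelled ligand from melanin-concentrating hormone receptor 1 (Homo sapiens), with a stated time of 2 h (on this read-out higher numbers stand for weaker inhibition and lower numbers for stronger inhibition), the highest of the three numbers. Compound 2 `Cc1nc(N2CCN(C(=O)C3CC3)CC2)nc2ccc(NC(=O)COc3ccc(OC(F)(F)F)cc3)cc12` gives 49 nM, and compound 3 `Cc1nc(N2CCC(O)(C3CC3)CC2)nc2ccc(NC(=O)COc3ccc(OC(F)(F)F)cc3)cc12` gives 101 nM. The measured steps, a 2.4-fold lower number from compound 1 to compound 2 (0.37 log units; beyond the scatter), a 1.1-fold lower number from compound 1 to compound 3 (0.06 log units; within the scatter) and a 2.1-fold higher number from compound 2 to compound 3 (0.31 log units; beyond the scatter), all change the saturated amine ring on the shared core and leave the phenoxy arm as it is. For the measured compounds named here, compound 4 `CCC1(O)CCN(c2nc(C)c3cc(NC(=O)COc4ccc(Cl)cc4)ccc3n2)CC1` differs from compound 1 by chloro in place of trifluoromethoxy on an aromatic carbon, a change that none of the measured steps touches, so no direct guidance exists. The expectation for compound 4 is therefore a step of a 1.3-fold higher number from compound 1 to compound 4 (0.11 log units; within the scatter) that stays within the scatter. Compound 4 is estimated at 150 nM in this assay, with a range of 50 nM to 450 nM.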

Compound 4, half-maximal inhibitory concentration: 208 nM
Beside the measured number, compound 4's estimate is 1.4-fold (0.14 log units) below it; low and high end bracket the measured number.
By their numbers in this assay, from the lowest: compound 2; then compounds 3, 1 and 4 (each within the scatter of the next, the first and the last beyond it).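

Moving to the phenoxy arm for the first time in this assay, the exchange of trifluoromethoxy for chloro, on an aromatic carbon para to a large group, gives a 1.8-fold higher number from compound 1 to compound 4 (0.25 log units; within the scatter). With the 4-ethyl-4-hydroxypiperidin-1-yl group in place, this position therefore accepts chloro with a step that stays within the scatter. No measurement shown explains this result.

As far as these compounds go, whether chloro behaves the same way alongside the 4-(cyclopropylcarbonyl)piperazin-1-yl group of compound 2 remains open. So does the outcome at this position with fluoro, methyl or a nitrile.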